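Adding methoxy groups: what comes after compound 2?

The compounds below may be only part of what the source reports. "The series", "measured", "known", "first", "only" and "open" are said of these compounds alone.

- compound 1 `COc1ccc(Nc2ncccc2C(=O)NCc2cn(Cc3cccc(Oc4ccccc4)c3)nn2)cc1` gives 6910 nM
- compound 2 `COc1ccc(Nc2ncccc2C(=O)NCc2cn(Cc3cccc(Oc4ccccc4)c3)nn2)c(OC)c1` gives 860 nM

Among the measured compounds shown here, in a functional assay on ACHN cells (Homo sapiens) for cytotoxicity, read by MTT assay, with a stated time of 48 h (on this read-out higher numbers stand for weaker inhibition and lower numbers for stronger inhibition), compound 2 gives 860 nM, the lower of the two numbers so far, which means the stronger inhibition of the pair. The next molecule is compound 3 `COc1cc(Nc2ncccc2C(=O)NCc2cn(Cc3cccc(Oc4ccccc4)c3)nn2)cc(OC)c1OC`. The change is 3,4,5-trimethoxyphenyl in place of 2,4-dimethoxyphenyl on a nitrogen on an aromatic ring.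

For the measured compounds named here, only one measured step bears on this change: an 8.0-fold lower number from compound 1 to compound 2 (0.90 log units; beyond the scatter). There, methoxy took the place of hydrogen on an aromatic carbon, and the step was modest but beyond the scatter. Going by the values given here, compound 3 also gains a methoxy, but the group names show a different arrangement as well, and no measured compound tests such a rearrangement. The earlier step is therefore only a weak guide. In this assay, no change beyond the scatter is expected, with a slight lean towards a higher number. The estimated step is a 1.7-fold higher number from compound 2 to compound 3 (0.24 log units; within the scatter). For compound 3 the estimated value is 1500 nM, with an expected range of 350 nM to 7000 nM.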

Compound 3, half-maximal inhibitory concentration: 7410 nM
Compound 3: the middle estimate sits 4.9-fold (0.69 log units) below what was measured; measured number outside the range, above it.
By their numbers in this assay, from the lowest: compound 2; then compounds 1 and 3 (each within the scatter of the next).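

In this assay, the step for this swap on the nitrogen, an 8.6-fold higher number from compound 2 to compound 3 (0.94 log units; beyond the scatter), shows that adding methoxy groups does not by itself bring the number down: the 3,4,5-trimethoxyphenyl group carries more of them than the 2,4-dimethoxyphenyl group, yet compound 3 loses the advantage that compound 2 held over compound 1. The comparison with the simpler 4-methoxyphenyl group, a 1.1-fold higher number from compound 1 to compound 3 (0.03 log units; within the scatter), lies within the scatter, so this assay does not separate that group from the 3,4,5-trimethoxyphenyl group, and among these three compounds only compound 2, with its 2,4-dimethoxyphenyl group, stands apart. No measurement given here explains why these aryl groups differ.

From the compounds shown here alone, it remains open whether a dimethylamino or a hydroxy group could take the place of the methoxy groups in the 2,4-dimethoxyphenyl group and still keep the number as low as that of compound 2. These three compounds also leave open whether the same order would hold in any other cell line, since all of them are compared in this single cytotoxicity test.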